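The source may hold more compounds than are shown below. What is called first, only, known or untested is meant among the compounds shown, and "the series" means these compounds.

Working notes on the series. In a functional assay on K562 cells (Homo sapiens) for cytotoxicity, read by sulforhodamine B assay (on this read-out higher numbers stand for weaker inhibition of growth and lower numbers for stronger inhibition of growth), compound 1 (`CC1=CC[C@@H]([C@@](C)(O)CCCC(C)(C)NC=S)CC1`) gives 16700 nM, compound 3 (`CC1=CC[C@@H]([C@@](C)(O)CCCC(C)(C)NC(=S)N/N=C\c2ccc(O)cc2)CC1`) gives 600 nM, and compound 2 (`COc1ccc(/C=N\NC(=S)NC(C)(C)CCC[C@](C)(O)[C@@H]2CC=C(C)CC2)cc1`) gives 220 nM. Compound 2 thus holds the lowest of the three numbers, with compound 3 nearest and compound 1 furthest.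

Compound 4 (`CC1=CC[C@@H]([C@@](C)(O)CCCC(C)(C)NC(=S)N/N=C\c2ccc([N+](=O)[O-])cc2)CC1`) has no value yet. It departs from compound 2 at one place: nitro in place of methoxy on an aromatic carbon. This puts nitro in place of methoxy on an aromatic carbon, para to a large group.

Among the measured compounds shown here, only one measured step touches that methoxy: a 2.7-fold higher number from compound 2 to compound 3 (0.44 log units; beyond the scatter), with hydrogen in place of methyl on an oxygen on an aromatic ring. For the measured compounds named here, that step was modest and beyond the scatter, and no measured compound yet carries nitro, so it is only a loose guide. A step of similar modest size is expected in this assay, towards a higher number. The expected move is a 2.3-fold higher number from compound 2 to compound 4 (0.36 log units; beyond the scatter). For compound 4 the estimated value is 500 nM, with an expected range of 150 nM to 1700 nM.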

Compound 4, concentration for 50% growth inhibition: 4220 nM
Estimate against measurement, compound 4: 8.4-fold (0.93 log units) below; measured number outside the range, above it.
By their numbers in this assay, from the lowest: compound 2; then compound 3; then compound 4; then compound 1.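

In this assay, among the compounds shown here, the group on this aromatic carbon, para to a large group, matters far more than the one step through the methoxy suggested: nitro in place of methoxy gives a 19-fold higher number from compound 2 to compound 4 (1.28 log units; beyond the scatter), a large step. Nitro in place of hydroxy gives a 7.0-fold higher number from compound 3 to compound 4 (0.85 log units; beyond the scatter), so in these compounds the nitro compound stands apart from both the methoxy and the hydroxy compounds, whereas the step between those two, a 2.7-fold higher number from compound 2 to compound 3 (0.44 log units; beyond the scatter), is much smaller. Nothing at hand gives a reason for this gap.

Whether the loss belongs to nitro alone remains open, as the compounds shown carry only three groups at this carbon. An amine, a nitrile, a trifluoromethyl or a chlorine at the same place would show how far the nitro result extends.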